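Series notes: from compound 1 to compound 4

A few compounds are considered here, and "the series" means these few. Any claim that something is new, unique, unknown or untested is made for them only; others in the source may bear on it.

Measured so far, in an ADME assay on Caco-2 cells (Homo sapiens) for permeability, in the apical to basolateral direction; a higher number here means that the compound crosses the layer faster, a lower number that the compound crosses the layer more slowly:
- compound 1 `COC(=O)N1CCN([C@H]2CC[C@H](Nc3ncnn4ccc([C@H](C)CC(=O)N(C)C)c34)CC2)CC1`: 18 10^-6 cm/s
- compound 2 `CN(C)[C@H]1CC[C@H](Oc2ncnn3ccc([C@H]4CC[C@H](C(N)=O)CC4)c23)CC1`: < 2 10^-6 cm/s, a limit of the assay, not a number
- compound 3 `CC(C)n1ccc2ncnc(N[C@H]3CC[C@H](N(C)C)CC3)c21`: 4.2 10^-6 cm/s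

Compound 1 has the higher of the two numbers in this assay; compound 3 sits lower, and the gap lies beyond the scatter. Compound 2 only reaches the limit of the assay (the limit of < 2 10^-6 cm/s in this assay, at which 1 of the 3 values shown sits), so no number stands for it.

Compound 4 `COC(=O)N1CCN([C@H]2CC[C@H](Nc3ncnn4ccc(C(C)C)c34)CC2)CC1` is still to be measured. It differs from compound 1 in one place: hydrogen in place of dimethylcarbamoyl on a saturated chain carbon, two bonds along the chain from an aromatic carbon. For the measured compounds named here, no measured pair here shows the same change, so the expected step rests on compound 1 alone.

The step of a 1.7-fold higher number from compound 1 to compound 4 (0.22 log units; within the scatter) is expected to run upward, modestly and at the edge of the scatter. For compound 4 the estimate in this assay is 30 10^-6 cm/s, with a range from 15 10^-6 cm/s to 60 10^-6 cm/s.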

Compound 4, apparent permeability: 37 10^-6 cm/s
Compound 4: middle estimate off by 1.2-fold (0.09 log units), on the low side, and the stated range covers the measured number.
By their numbers in this assay, from the lowest: compound 3; then compound 1; then compound 4. At a limit, below all of these: compound 2.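

In this assay, for the compounds shown here, the change from 1-((dimethylcarbamoyl)methyl)ethyl to isopropyl gives a 2.1-fold higher number from compound 1 to compound 4 (0.31 log units; beyond the scatter) and is the first single change that can be read. The step is modest, but it shows that a high number at this position does not require the dimethylcarbamoyl group. Nothing at hand gives a cause for this step.

This one pair cannot show whether the same change would give a similar step on another core or with a different group on the saturated ring. From the compounds shown here alone, how a carboxylic acid or a hydroxyl group in place of dimethylcarbamoyl on this saturated chain carbon would read in this assay remains open.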